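This account rests on a few compounds, and the source may have more. Where it says the series, first, only, none or still open, it means among the compounds named here.

The shared core of compound 1 `CN(C)S(=O)(=O)c1ccc(F)c(C#Cc2cc(Cl)ccc2OCC(=O)O)c1` is carried, with different substituents, by compound 2 `COc1ccccc1C#Cc1cc(Cl)ccc1OCC(=O)O` and compound 3 `Cc1ccc(S(=O)(=O)Cc2ccccc2)cc1C#Cc1cc(Cl)ccc1OCC(=O)O`. In an assay on CHO cells for displacement of a labelled ligand from prostaglandin D2 receptor 2 (Homo sapiens), read by scintillation counting (on this read-out lower numbers stand for stronger inhibition and higher numbers for weaker inhibition), compound 1 gives 3.1 nM. Compound 3 gives 5 nM, which lies within the scatter of compound 1. Compound 2 gives 190 nM, a gap from compound 1 that lies beyond the scatter. Compound 4 `CCCS(=O)(=O)c1ccc(F)c(C#Cc2cc(Cl)ccc2OCC(=O)O)c1` differs from compound 1 in one place: propyl in place of dimethylamino on a sulfonyl sulfur. Going by the values given here, no pair of measured compounds shows a change of this kind, so there is no precedent among them. The change is expected to move the number little, and a 1.3-fold higher number from compound 1 to compound 4 (0.11 log units; within the scatter) is the step estimated here, not beyond the scatter. In this assay compound 4 is expected to give 4 nM, within a range from 1.5 nM to 10 nM.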

Compound 4, inhibition constant: 3.4 nM
Compound 4: middle estimate off by 1.2-fold (0.07 log units), on the high side; measured number inside the range.
By their numbers in this assay, from the lowest: compounds 1, 4 and 3 (each within the scatter of the next); then compound 2.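

In this assay, propyl in place of dimethylamino on a sulfonyl sulfur gives a 1.1-fold higher number from compound 1 to compound 4 (0.04 log units; within the scatter). This is the only one-place pair among the compounds shown, and it establishes what compounds 2 and 3 could not: the sulfonyl sulfur tolerates losing its nitrogen, since dimethylsulfamoyl and propylsulfonyl read alike here.

As far as these compounds go, whether a longer chain such as hexyl, a ring such as morpholine, or a carboxylic acid on that sulfur would read the same remains open. Nothing shown explains why the two groups read alike.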